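Chloro to Trifluoromethyl on the Substituted Aryl Ring

The compounds below may be only part of what the source reports. "The series", "measured", "known", "first", "only" and "open" are said of these compounds alone.

Three measured compounds share one core and differ only in the group on the six-membered aromatic ring of carbon only. Compound 1 `COc1ccc(CNc2nc(-c3ccccc3C(F)(F)F)nc3ccccc23)cc1` carries a methoxy, and in an assay on a protein complex for inhibition of ubiquitin carboxyl-terminal hydrolase 1/WD repeat-containing protein 48 (Homo sapiens), read by fluorescence (on this read-out lower numbers stand for stronger inhibition and higher numbers for weaker inhibition), compound 1 gives 6200 nM. Compound 2 `Fc1ccc(CNc2nc(-c3ccccc3C(F)(F)F)nc3ccccc23)cc1` carries a fluoro, and in this assay compound 2 gives 3400 nM. Compound 3 `FC(F)(F)c1ccccc1-c1nc(NCc2ccc(Cl)cc2)c2ccccc2n1` carries a chloro, and in this assay compound 3 gives 4800 nM. The steps among them, a 1.8-fold lower number from compound 1 to compound 2 (0.26 log units; within the scatter), a 1.3-fold lower number from compound 1 to compound 3 (0.11 log units; within the scatter) and a 1.4-fold higher number from compound 2 to compound 3 (0.15 log units; within the scatter), all lie within the scatter, so compound 3 stands together with the other two rather than apart from them. Compound 4 `FC(F)(F)c1ccc(CNc2nc(-c3ccccc3C(F)(F)F)nc3ccccc23)cc1` differs from compound 3 by trifluoromethyl in place of chloro on an aromatic carbon. The measured steps that bear on this change are those three exchanges of the group at the same place, none of them beyond the scatter, and they give no reason to expect a step in this assay beyond the scatter in either direction. Compound 4 is therefore expected to give about 4500 nM in this assay, with a range from 1800 nM to 11000 nM, meaning an expected step of a 1.1-fold lower number from compound 3 to compound 4 (0.03 log units; within the scatter).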

Compound 4, half-maximal inhibitory concentration: 8900 nM
Estimate against measurement, compound 4: 2.0-fold (0.30 log units) below; the range from low to high includes it.
By their numbers in this assay, from the lowest: compounds 2, 3, 1 and 4 (each within the scatter of the next, the first and the last beyond it).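

In this assay, the trifluoromethyl group gives the only step beyond the scatter among these four compounds at this position (a 2.6-fold higher number from compound 2 to compound 4 (0.42 log units; beyond the scatter)), and that step is modest. The other two new steps (a 1.9-fold higher number from compound 3 to compound 4 (0.27 log units; within the scatter) and a 1.4-fold higher number from compound 1 to compound 4 (0.16 log units; within the scatter)) remain within the scatter, so compound 4 separates from compound 2 alone, and the methoxy, fluoro, chloro and trifluoromethyl groups otherwise form one overlapping run with fluoro and trifluoromethyl at its two ends. No measurement at hand explains the gap between the fluoro and trifluoromethyl compounds.

The compounds shown leave open how an amine, a carboxylic acid or a longer chain at this position would read in this assay. They also leave open whether the step from fluoro to trifluoromethyl would hold with a different group in place of the trifluoromethyl on the other aromatic ring.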